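The source may report more compounds than this note shows. Statements on the series, on what has been measured and on what is new or still open speak of the compounds shown alone.

Three compounds share one core and differ only in the group on a saturated chain carbon bound to a sulfur. Compound 1 `Cc1cc(Nc2cc(-c3ccccc3)[nH]n2)n2nc(SCc3csc4ccccc34)nc2n1` gives 29200 nM in an ADME assay on GES1 cells (Homo sapiens) for inhibition, read by MTT assay, with a stated time of 72 h; a lower number here means a stronger inhibitor, a higher number a weaker inhibitor. Compound 2 `Cc1cc(Nc2cc(-c3ccccc3)[nH]n2)n2nc(SCc3ccc(Cl)cc3)nc2n1` gives 31800 nM in this assay, and compound 3 `Cc1cc(Nc2cc(-c3ccccc3)[nH]n2)n2nc(SCCc3ccccc3)nc2n1` gives 37400 nM in this assay. The steps to compound 3 are small: a 1.3-fold higher number from compound 1 to compound 3 (0.11 log units; within the scatter) and a 1.2-fold higher number from compound 2 to compound 3 (0.07 log units; within the scatter), so its number is not separated from either of the other two. Compound 4 `Cc1cc(Nc2cc(-c3ccccc3)[nH]n2)n2nc(SCc3cccc4ccccc34)nc2n1` has not yet been measured in this assay. It differs from compound 3 in one place: naphthalen-1-yl in place of benzyl on a saturated chain carbon bound to a sulfur. Among the compounds with values here, the steps that bear on this change are those that exchange the group at this same place, namely a 1.3-fold higher number from compound 1 to compound 3 (0.11 log units; within the scatter), a 1.2-fold higher number from compound 2 to compound 3 (0.07 log units; within the scatter) and a 1.1-fold higher number from compound 1 to compound 2 (0.04 log units; within the scatter), and none of them moves the number beyond the scatter. Compound 4 is therefore expected to show no step beyond the scatter, a 1.1-fold lower number from compound 3 to compound 4 (0.05 log units; within the scatter). The estimate for compound 4 in this assay is 33000 nM, with a range from 15000 nM to 75000 nM.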

Compound 4, half-maximal inhibitory concentration: 36300 nM
The estimate for compound 4 lay 1.1-fold (0.04 log units) below the measured number; the measured number falls inside the stated range.
By their numbers in this assay, from the lowest: compounds 1, 2, 4 and 3 (each within the scatter of the next).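

Exchanging benzyl for naphthalen-1-yl, which brings two six-membered aromatic rings of carbon in place of one, gives a 1.0-fold lower number from compound 3 to compound 4 (0.01 log units; within the scatter) in this assay. The new group also stays level with the other two: in place of 4-chlorophenyl it gives a 1.1-fold higher number from compound 2 to compound 4 (0.06 log units; within the scatter), and in place of 1-benzothiophen-3-yl it gives a 1.2-fold higher number from compound 1 to compound 4 (0.09 log units; within the scatter). With this fourth group, all the exchanges shown on a saturated chain carbon bound to a sulfur remain within the scatter, including the one that adds carbon atoms and a second ring to benzyl.

No measurement at hand explains why these numbers stay together. As far as these compounds go, all four groups carry aromatic rings, so it remains open whether an amine or a carboxylic acid at this place would move the number beyond the scatter.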